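The compounds below may be only part of what the source reports. "The series", "measured", "known", "first", "only" and "open" are said of these compounds alone.

Compound 1 `COc1cc(-c2nc3cc(/C=C4\SC(=O)N(Cc5ccccc5)C4=O)ccc3[nH]2)cc(OC)c1OC`: 950 nM
Compound 2 `COc1cc(-c2nc3cc(/C=C4\SC(=O)N(Cc5cccc(C)c5)C4=O)ccc3[nH]2)cc(OC)c1OC`: 1440 nM

In a functional assay on HeLa cells (Homo sapiens) for inhibition, read by MTT assay, with a stated time of 48 h (a higher number here means a weaker inhibitor, a lower number a stronger inhibitor), compound 1 gives 950 nM, and compound 2 gives 1440 nM. Of the two numbers, that of compound 2 is the larger, but the step of a 1.5-fold higher number from compound 1 to compound 2 (0.18 log units; within the scatter) lies within the scatter, so the two compounds are not separated by this assay. Compound 3 `COc1cc(CN2C(=O)S/C(=C\c3ccc4[nH]c(-c5cc(OC)c(OC)c(OC)c5)nc4c3)C2=O)cc(OC)c1OC` has not been measured; it differs from compound 2 by 3,4,5-trimethoxyphenyl in place of 3-methylphenyl on a saturated chain carbon bound to an amide-type nitrogen in a ring. Within the data shown here, the only measured step, a 1.5-fold higher number from compound 1 to compound 2 (0.18 log units; within the scatter), changed a group on the same saturated chain carbon bound to the ring amide-type nitrogen and produced no shift beyond the scatter. That step is the sole guide, and the replacement in compound 3 is a larger one, for which there is no precedent among the compounds shown. The expected step from compound 2 to compound 3 in this assay is a 1.0-fold lower number from compound 2 to compound 3 (0.01 log units; within the scatter), small and of uncertain direction. Compound 3 is therefore estimated at 1400 nM, with a range from 550 nM to 3600 nM.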

Compound 3, half-maximal inhibitory concentration: 2240 nM
The estimate for compound 3 lay 1.6-fold (0.20 log units) below the measured number; the measured number falls inside the stated range.
By their numbers in this assay, from the lowest: compounds 1, 2 and 3 (each within the scatter of the next, the first and the last beyond it).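

In this assay, among these compounds, the 3,4,5-trimethoxyphenyl group on the saturated chain carbon bound to an amide-type nitrogen in a ring gives the first step at this position beyond the scatter, a 2.4-fold higher number from compound 1 to compound 3 (0.37 log units; beyond the scatter) when it replaces phenyl, though the step is only modest. Measured against the 3-methylphenyl of compound 2, the same group gives a 1.6-fold higher number from compound 2 to compound 3 (0.19 log units; within the scatter) and so is not separated, which means a clear difference appears only against the unsubstituted phenyl. This position therefore tolerates a group with three methoxy substituents on the ring, with the number staying in the same broad range, but nothing shown gives a reason for the step.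

The compounds shown leave open whether a single methoxy group on the phenyl ring would give the same number as all three together. They also leave open what an amine or a carboxylic acid on that ring, or a longer chain in place of the single saturated carbon, would do to the number.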